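This account rests on a few compounds, and the source may have more. Where it says the series, first, only, none or still open, it means among the compounds named here.

Working notes on the series. In an ADME assay on BaF3 cells (Mus musculus) for cytotoxicity (on this read-out lower numbers stand for an effect already at smaller amounts and higher numbers for an effect only at larger amounts of compound), compound 1 `CN1CCN(C(=O)c2cc3c(Nc4ccc(OC(F)(F)F)cc4)ncnc3s2)CC1` gives 2690 nM, compound 2 `CS(=O)(=O)Nc1ccc(-c2cc(Nc3ccc(OC(F)(F)F)cc3)ncn2)cc1` gives 2210 nM, and compound 3 `CCCn1ncc2c(Nc3ccc(OC(F)(F)F)cc3)ncnc21` gives 6600 nM. Compound 2 carries the smallest of the three numbers, though its gap to compound 1 lies within the scatter; only compound 3 stands apart, with a number beyond the scatter on the higher side. For the measured compounds named here, no pairwise step between measured compounds is available here. Compound 4 `NC(=O)c1ccc(-c2cc(Nc3ccc(OC(F)(F)F)cc3)ncn2)cc1` is not yet measured in this assay; it differs from compound 2 by carbamoyl in place of methanesulfonamido on an aromatic carbon. With nothing comparable among the measured compounds, no step beyond the scatter is expected in either direction for this change. Compound 4 is therefore estimated at 2500 nM, in a range from 1000 nM to 6500 nM, meaning an expected step of a 1.1-fold higher number from compound 2 to compound 4 (0.05 log units; within the scatter).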

Compound 4, half-maximal effective concentration: > 10000 nM
Compound 4: only a limit was reported; the forecaster's own chance of this, stated with the estimate: 10%; at least 4.0-fold (0.60 log units) between middle value and limit.
By their numbers in this assay, from the lowest: compounds 2 and 1 (each within the scatter of the next); then compound 3. At a limit, above all of these: compound 4.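

Carbamoyl in place of methanesulfonamido on an aromatic carbon, para to a large group, gives an at least 4.5-fold higher number from compound 2 to compound 4 (0.65 log units; beyond the scatter) in this assay, so this position is not indifferent to the change. Compound 4 reads > 10000 nM, which is a limit of the assay and not a number. The step is therefore bounded on one side only, and it rests on a single value at that limit: the limit of > 10000 nM in this assay, at which 1 of the 4 values shown sits.

Open, going by these compounds, is whether a carboxylic acid, a nitrile or an amine at this place would read like compound 2 or like compound 4. Also open, on these data alone, is whether the same change would carry over to the cores of compound 1 and compound 3.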